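The compounds below may be only part of what the source reports. "The series", "measured", "known", "first", "only" and "open" are said of these compounds alone.

Measured so far in an assay on cells for inhibition of histone-lysine N-methyltransferase EZH2 (Homo sapiens), read by ELISA, with a stated time of 72 h; a lower number here means a stronger inhibitor, a higher number a weaker inhibitor:
- compound 1 `Cc1cc(C)c(CN2CCc3c(Cl)cc([C@H](CO)[C@H]4CCOC4)c(Cl)c3C2=O)c(=O)[nH]1` — 10 nM
- compound 2 `COC(c1cc(Cl)c2c(c1Cl)C(=O)N(Cc1c(C)cc(C)[nH]c1=O)CC2)C1CCOCC1` — 1460 nM; 9 nM (2 entries)

Among the compounds with values here, compound 1 is the one compound of the pair with a single value in this assay; compound 2 carries several entries that lie far apart from one another, (the several entries of compound 2 in this assay, 1460 nM; 9 nM (2 entries)), so it offers no firm point of comparison. Within the data shown here, no pair of measured compounds differs in one place, so no measured step is available.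

Compound 3 `Cc1cc(C)c(CN2CCc3c(Cl)cc([C@@H](CO)[C@@H]4CCCO4)c(Cl)c3C2=O)c(=O)[nH]1` is the next member, not yet measured. It differs from compound 1 by a group of 8 heavy atoms (6 carbon, 2 oxygen; one five-membered non-aromatic ring with 1 hetero atom) in place of a group of 8 heavy atoms (6 carbon, 2 oxygen; one five-membered non-aromatic ring with 1 hetero atom), on an aromatic carbon: the same atoms, joined differently, with the five-membered ring attached through a different ring carbon and both stereocentres defined afresh.

Among the measured compounds shown here, with no measured step to lean on, the expected step in this assay is small, at most a slight loss, and an outcome within the usual scatter is as plausible as any; the expected step is a 2.0-fold higher number from compound 1 to compound 3 (0.30 log units; within the scatter). Compound 3 is estimated at 20 nM, with a range of 5 nM to 80 nM.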

Compound 3, half-maximal inhibitory concentration: 1570 nM
Compound 3: the middle estimate sits 79-fold (1.89 log units) below what was measured, outside the stated range (above it).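

At the position on an aromatic carbon, ortho to a chloro group, this assay responds strongly to how the group is connected: the change gives a 160-fold higher number from compound 1 to compound 3 (2.20 log units; beyond the scatter), although the group that leaves and the group that enters have the same atoms and the same counts of donors and acceptors. Composition alone therefore does not set the read-out here; the arrangement of the same atoms does. Nothing shown gives a cause for this step.

The ring attachment point and both stereocentres change together in this one step, so the share of each in the loss stays unresolved. Also open, as far as these compounds go, is how an amine or a morpholine at this position would read out against compound 1.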